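Phenoxy Replacing Thiophen-3-yl on a Shared Pyrimidine-Like Core

The source may hold more compounds than are shown below. What is called first, only, known or untested is meant among the compounds shown, and "the series" means these compounds.

Measured compounds:
compound 1, `CCOC(=O)c1cnc(SC)nc1NN1C(=O)C=C(C)C1=O`, 200 nM
compound 2, `CCOC(=O)c1cnc(-c2ccsc2)nc1NN1C(=O)C=C(C)C1=O`, 100 nM

In a functional assay on Jurkat cells for inhibition of nuclear factor NF-kappa-B complex (Homo sapiens) (a higher number here means a weaker inhibitor, a lower number a stronger inhibitor), compound 2 gives the lowest of the two numbers recorded so far, and its nearest neighbour is compound 1, from which it differs by thiophen-3-yl in place of methylsulfanyl on an aromatic carbon; that step, a 2.0-fold lower number from compound 1 to compound 2 (0.30 log units; within the scatter), is small enough to count as noise in this assay.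

Compound 3, `CCOC(=O)c1cnc(Oc2ccccc2)nc1NN1C(=O)C=C(C)C1=O`, has not yet been measured. It differs from compound 2 at the same aromatic carbon, between two ring nitrogen atoms and para to the ethoxycarbonyl group: phenoxy in place of thiophen-3-yl on an aromatic carbon.

Among the measured compounds shown here, only one measured step bears on this change, namely the one from compound 1 to compound 2, which swapped groups at this same position and stayed within the scatter. Nothing here shows that altering this group moves this assay by more than the scatter, so the step from compound 2 to compound 3 is expected to be modest, with no firm direction: a 1.4-fold higher number from compound 2 to compound 3 (0.15 log units; within the scatter). Compound 3 is therefore estimated to give about 140 nM in this assay, within a range of 50 nM to 400 nM.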

Compound 3, half-maximal inhibitory concentration: 15000 nM
Estimate against measurement, compound 3: 110-fold (2.03 log units) below, and the stated range ends below it.
By their numbers in this assay, from the lowest: compounds 2 and 1 (each within the scatter of the next); then compound 3.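

In this assay, the aromatic carbon between two ring nitrogen atoms proves far from indifferent to its substituent: phenoxy in place of thiophen-3-yl gives a 150-fold higher number from compound 2 to compound 3 (2.18 log units; beyond the scatter), a large loss of inhibition. Phenoxy in place of methylsulfanyl gives a 75-fold higher number from compound 1 to compound 3 (1.88 log units; beyond the scatter), also large, so the loss appears against both earlier groups, even though those two groups stay within the scatter of each other. The swap from thiophen-3-yl to phenoxy leaves the counts of hydrogen-bond donors and acceptors unchanged, so those counts do not separate compound 2 from compound 3; what does change is that an oxygen now links the ring to the core, and that ring is a six-membered carbon ring rather than a five-membered ring with sulfur.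

Nothing measured here explains why the number rises so sharply. The compounds shown also cannot separate the effect of the oxygen link from that of the ring, a question that a directly attached phenyl or an anilino group at this position would help to answer.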